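A few compounds are considered here, and "the series" means these few. Any claim that something is new, unique, unknown or untested is made for them only; others in the source may bear on it.

Working notes on the series. Compound 1 `CC(C)=CCC[C@]1(C)/C=C/[C@@H](OC(=O)C=C(C)C)[C@](C)(O)/C=C/C(=O)/C(CCl)=C\C1` in a functional assay on MCF7 cells (Homo sapiens) for antiproliferative activity, read by MTT assay, with a stated time of 48 h (on this read-out higher numbers stand for weaker inhibition and lower numbers for stronger inhibition), gives 610 nM, the lowest of the two numbers in hand. Compound 2 `CC(C)=CCC[C@]1(C)/C=C/[C@@H](OC(=O)C=C(C)C)[C@](C)(O)/C=C/C(=O)/C(C[Si](c2ccccc2)(c2ccccc2)C(C)(C)C)=C\C1` gives 15800 nM in this assay, a higher number by a step beyond the scatter. Compound 3 `CC(C)=CCC[C@]1(C)/C=C/[C@@H](OC(=O)C=C(C)C)[C@](C)(O)CCC(=O)/C(CO)=C\C1` reaches only a limit of the assay in this assay, > 40000 nM; this is the limit of > 40000 nM in this assay, at which 1 of the 3 values shown sits.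

Compound 4 `CC(C)=CCC[C@]1(C)/C=C/[C@@H](OC(=O)C=C(C)C)[C@](C)(O)/C=C/C(=O)/C(Cn2cc(CO)nn2)=C\C1` has not been measured in this assay. It differs from compound 1 in one place: 4-(hydroxymethyl)-1H-1,2,3-triazol-1-yl in place of chloro on a saturated chain carbon bound to a double-bonded ring carbon.

Within the data shown here, no measured step of this kind is in hand. The expectation for this assay is a step from compound 1 to compound 4 toward weaker inhibition, beyond the scatter, of about a 9.8-fold higher number from compound 1 to compound 4 (0.99 log units; beyond the scatter). Compound 4 is therefore estimated at 6000 nM in this assay, expected to fall between 1500 nM and 25000 nM.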

Compound 4, half-maximal inhibitory concentration: 2930 nM
Beside the measured number, compound 4's estimate is 2.0-fold (0.31 log units) above it; the range from low to high includes it.
By their numbers in this assay, from the lowest: compound 1; then compound 4; then compound 2. At a limit, above all of these: compound 3.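

In this assay, 4-(hydroxymethyl)-1H-1,2,3-triazol-1-yl in place of chloro gives a 4.8-fold higher number from compound 1 to compound 4 (0.68 log units; beyond the scatter) on this saturated chain carbon bound to a double-bonded ring carbon, the first step read in one place in the series. The position thus takes a group of 7 heavy atoms with a five-membered aromatic ring and still gives a measured number, though chloro stays ahead. No measured property bears on the reason for this step. On these data alone, whether the ring or its hydroxymethyl sets the size of the step stays open. As far as these compounds go, how an amine or a carboxylic acid on this carbon would read in this assay against chloro also stays open.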